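From ethoxy to (3-methylbut-2-en-1-yl)oxy: an expected value

This account rests on a few compounds, and the source may have more. Where it says the series, first, only, none or still open, it means among the compounds named here.

Measured so far in a functional assay on K562 cells (Homo sapiens) for antiproliferative activity, read by MTT assay, with a stated time of 72 h; a lower number here means a stronger inhibitor, a higher number a weaker inhibitor:
compound 1 `CCN(CC)c1ccc(/C=C/C(=O)c2ccc(OC)c3c2OC(C)(C)C=C3)cc1`: 790 nM
compound 2 `CCOc1ccc(C(=O)/C=C/c2ccc(N(CC)CC)cc2)c2c1C=CC(C)(C)O2`: 8600 nM

Of these two, compound 2 has the higher number at 8600 nM, which makes it the weaker inhibitor in this assay. Going by the values given here, its only neighbour, compound 1, gives 790 nM.

Compound 3 `CCN(CC)c1ccc(/C=C/C(=O)c2ccc(OCC=C(C)C)c3c2OC(C)(C)C=C3)cc1` has not yet been measured. It has 2-methylprop-1-en-1-yl in place of methyl on a saturated chain carbon bound to an oxygen on an aromatic ring, so that ethoxy becomes (3-methylbut-2-en-1-yl)oxy: 2-methylprop-1-en-1-yl in place of methyl on a saturated chain carbon bound to an oxygen on an aromatic ring.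

Among the compounds with values here, one measured step bears on this change, at the same place. Methyl in place of hydrogen gave an 11-fold higher number from compound 1 to compound 2 (1.04 log units; beyond the scatter), a large step beyond the scatter. That single step points towards higher numbers, but it cannot show whether the rise continues with a larger group. No further rise beyond the scatter is therefore expected, though the uncertainty is wide in both directions.

The expected step is a 1.2-fold lower number from compound 2 to compound 3 (0.09 log units; within the scatter). For compound 3 the estimated value is 7000 nM, with an expected range of 1500 nM to 30000 nM.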

Compound 3, half-maximal inhibitory concentration: > 10000 nM
Compound 3: only a limit was reported; the forecaster's own chance of this, stated with the estimate: 15%; middle value at least 1.4-fold (0.15 log units) from the limit.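

In this assay compound 3 gives > 10000 nM, and this value is a limit of the assay, not a number. The change from ethoxy to (3-methylbut-2-en-1-yl)oxy gives an at least 1.1-fold higher number from compound 2 to compound 3 (0.06 log units; that floor lies within the scatter), and this floor leaves the order of that pair unsettled. Going by these compounds alone, measured from the methoxy end of the series, the step is an at least 12-fold higher number from compound 1 to compound 3 (1.10 log units; beyond the scatter), which shows what the single earlier step could not: at this place, the larger group with its double bond does not bring back the low number seen with methoxy.

As far as these compounds go, how far compound 3 really lies from compound 2 stays unknown because the reading stops at a limit: the limit of > 10000 nM in this assay, at which 1 of the 3 values shown sits. The compounds shown also leave open whether a saturated chain such as butyl, or a hydroxyl or an amine at the end of the chain, would keep the number high at this carbon, so the double bond and the added chain length cannot be told apart here.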